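Removing a methyl from the core: compound 2 to compound 3

The source may report more compounds than this note shows. Statements on the series, on what has been measured and on what is new or still open speak of the compounds shown alone.

Measured compounds:
- compound 1, `COc1ccc(NC(=O)c2cccc(-c3cc(=O)c4c(OC)c(OC)c(OC)cc4o3)c2)cc1`: "not determined" (no result reported)
- compound 2, `COc1cc(NC(=O)c2cccc(-c3cc(=O)c4c(OC)c(OC)c(OC)cc4o3)c2)cc(OC)c1OC`: 3400 nM

Two compounds share one core here. Compound 1 carries a single methoxy on the outer ring, and in a functional assay on RAW264.7 cells (Mus musculus) for inhibition, with stated times of 1 h and 24 h (a higher number here means a weaker inhibitor, a lower number a stronger inhibitor), compound 1 gives "not determined" (no result reported) — no number exists for it. Compound 2 carries three methoxy groups on that outer ring, and in this assay compound 2 gives 3400 nM. Compound 2 thus stands alone on the numbers shown: its value is the only one, and nothing can be compared against it.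

The next compound, compound 3, `COc1cc(NC(=O)c2cccc(-c3cc(=O)c4c(O)c(OC)c(OC)cc4o3)c2)cc(OC)c1OC`, keeps everything of compound 2 and changes one place on the core: hydrogen in place of methyl on an oxygen on an aromatic ring.

Among the measured compounds shown here, no step between two measured compounds is available, so the size of this change in this assay cannot be read from anything already measured. The expectation is a step of no more than the scatter, in either direction. Compound 3 is expected to give an estimated 2500 nM, with a range from 800 nM to 8000 nM, which means an expected step of a 1.4-fold lower number from compound 2 to compound 3 (0.13 log units; within the scatter).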

Compound 3, half-maximal inhibitory concentration: 980 nM
Compound 3: the middle estimate sits 2.6-fold (0.41 log units) above what was measured; the range from low to high includes it.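

In this assay, replacing methoxy with hydroxy at this oxygen on the core gives a 3.5-fold lower number from compound 2 to compound 3 (0.54 log units; beyond the scatter), a step modest in size but beyond the usual scatter. Among the compounds shown here, this is the first measured step, and it shows that this position is not indifferent: losing a single methyl, one carbon, from the core is enough to make the compound a stronger inhibitor. Nothing available explains why the hydroxy compound gives the lower number, so the step stands as an observation only.

As far as these compounds go, this is one change at one place, so it remains open whether the same exchange at the other methoxy groups on the core would give a similar step, or whether this oxygen is special. From the compounds shown here alone, it also remains open what this position tolerates beyond hydrogen and methyl, for example whether a longer chain such as ethyl on the oxygen would give a higher number, or whether an amine in place of the hydroxy would keep the lower one.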